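Swapping the chloropyrimidine attachment on a longer chain

The compounds below may be only part of what the source reports. "The series", "measured", "known", "first", "only" and "open" are said of these compounds alone.

Three compounds have so far been measured in a physicochemical assay for solubility, read by HPLC, in phosphate buffer, with a stated time of 24 h, at pH 7.4; a higher number here means a more soluble compound, a lower number a less soluble compound:

Compound 1, `Clc1ccc2c(NCCCNc3nccc(Cl)n3)ccnc2c1`: 400 nM
Compound 2, `Clc1ccc2c(NCCCNc3ccnc(Cl)n3)ccnc2c1`: 600 nM
Compound 3, `Clc1ccc2c(NCCCCCCCCNc3nccc(Cl)n3)ccnc2c1`: 90 nM

Compound 1 and compound 2 differ in one place, (2-chloropyrimidin-4-yl in place of 4-chloropyrimidin-2-yl on an amine nitrogen). That change gave a 1.5-fold higher number from compound 1 to compound 2 (0.18 log units; within the scatter), so the two numbers cannot be told apart with confidence. Compound 3 carries the same 4-chloropyrimidin-2-yl group as compound 1, but the two cores differ; the difference between them is not broken down here. Compound 3 has the lowest number of the three: compound 1 is nearest to it and compound 2 furthest, and both gaps lie beyond the usual scatter.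

Compound 4, `Clc1ccc2c(NCCCCCCCCNc3ccnc(Cl)n3)ccnc2c1`, has not yet been measured. It differs from compound 3 by 2-chloropyrimidin-4-yl in place of 4-chloropyrimidin-2-yl on an amine nitrogen, the same change that separates compound 1 from compound 2, made at the same kind of place. Because that change gave a 1.5-fold higher number from compound 1 to compound 2 (0.18 log units; within the scatter), the step from compound 3 to compound 4 is expected to be small, about a 1.3-fold higher number from compound 3 to compound 4 (0.12 log units; within the scatter), with compound 4 staying close to compound 3 rather than rising toward compound 1 or compound 2. On that basis compound 4 is estimated to give 120 nM in this assay, most likely between 50 nM and 300 nM.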

Compound 4, solubility: 80 nM
Compound 4: middle estimate off by 1.5-fold (0.18 log units), on the high side; measured number inside the range.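

Carried onto the longer chain, 2-chloropyrimidin-4-yl in place of 4-chloropyrimidin-2-yl on an amine nitrogen gave, in this assay, a 1.1-fold lower number from compound 3 to compound 4 (0.05 log units; within the scatter) on that core and a 1.5-fold higher number from compound 1 to compound 2 (0.18 log units; within the scatter) on the core of compound 1 with its shorter chain. On both cores the two numbers of a pair cannot be told apart, so the result carried over in the one sense these data can support: the change left each pair within the usual scatter, and the fact that one step is printed as lower and the other as higher carries no weight. Among the compounds shown here, this does not show that the change is without effect on every core, since it rests on only two pairs, and no other measurement available here bears on the result.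

The compounds shown leave open whether the same holds on a chain of another length, or on a chain carrying an amine or a carboxylic acid. They also leave open what happens when the chlorine on the pyrimidine is replaced by an amine or a methoxy group, with the attachment swapped in the same way.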